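The source may hold more compounds than are shown below. What is called first, only, known or untested is meant among the compounds shown, and "the series" means these compounds.

Measured in a physicochemical assay for solubility, at pH 7; a higher number here means a more soluble compound, a lower number a less soluble compound:
- compound 1 `CC1(C)c2[nH]nc(NC(=O)c3ccc(F)cc3)c2CN1C(=O)C1CCN(C2CC2)CC1`: > 225000 nM
- compound 2 `CN(C)CC(=O)Nc1n[nH]c2c1CN(C(=O)C(C)(C)C)C2(C)C`: > 225000 nM
- compound 3 `CN1CCC(C(=O)N2Cc3c(NC(=O)c4ccc(F)c(F)c4)n[nH]c3C2(C)C)CC1`: > 225000 nM

Compound 1 reads > 225000 nM, which is a limit of the assay and not a number. Compound 2 and compound 3 also carry limits and not numbers. The measured set therefore offers no spread: what it shows is the limit of > 225000 nM in this assay, at which 3 of the 3 values shown sit. Nothing can be said about how these three compounds rank against one another.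

Compound 4 `CN1CCN(C(=O)N2Cc3c(NC(=O)c4ccc(F)cc4)n[nH]c3C2(C)C)CC1` has not yet been measured. It keeps the core of compound 1 and differs in one place: 4-methylpiperazin-1-yl in place of 1-cyclopropylpiperidin-4-yl on a carbonyl carbon. In words, this puts 4-methylpiperazin-1-yl in place of 1-cyclopropylpiperidin-4-yl on a carbonyl carbon.

Among the measured compounds shown here, no two measured compounds differ in only one place, so the data give no direct measure of what a change like this does. Since compound 1 reads > 225000 nM, I expect no step beyond the scatter in this assay, in either direction. The expected step is a number no higher from compound 1 to compound 4 (the limit leaves the size open). The assay will most likely report only a limit again. The estimate for compound 4 is 225000 nM, with an expected range from 120000 nM to 300000 nM.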

Compound 4, solubility: > 225000 nM
Compound 4: only a limit was reported (the forecaster's own chance of this, stated with the estimate: 85%); the middle value sits exactly at the limit.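

Among the compounds shown here, compound 1 and compound 4 each give only a limit and not a number in this assay, so no step between them can be read. How soluble each of the compounds shown actually is, and how they rank against one another, stays open, as all of them share a single limit: the limit of > 225000 nM in this assay, at which 4 of the 4 values shown sit.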